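This account rests on a few compounds, and the source may have more. Where it says the series, first, only, none or still open, it means among the compounds named here.

Measured compounds:
compound 1 `C/C(C(=O)NC1CC1)=C(\C)c1ccc(Br)cc1` – in a toxicity assay on the whole organism (strain Icem-CET (SPF Caw)) for cytotoxicity, with Mus musculus as the target (a higher number here means that more compound is needed for the effect, a lower number that less compound is needed), compound 1 gives 450 mg/kg
compound 2 `C=CCNC(=O)/C(C)=C(\C)c1ccc(Br)cc1` – in this assay compound 2 gives 500 mg/kg
compound 3 `C/C(C(=O)NC1CC1)=C(/C)c1ccc(Br)cc1` – in this assay compound 3 gives 600 mg/kg

Compound 3 holds the highest of the three numbers, but its neighbours sit close: a 1.2-fold higher number from compound 2 to compound 3 (0.08 log units; within the scatter) and a 1.3-fold higher number from compound 1 to compound 3 (0.12 log units; within the scatter). Neither step leaves the scatter, so the three compounds are not separated by this readout. The step from compound 1 to compound 3 rests on (the fact that compounds 1 and 3 differ only in the configuration as drawn), the step from compound 2 to compound 3 on the exchange of the amide substituent; both changes leave the number essentially where it was.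

Compound 4 `C/C(C(=O)NC1CC1)=C(/C)c1ccc(Cl)cc1` is not yet measured. It differs from compound 3 by chloro in place of bromo on an aromatic carbon. Among the measured compounds shown here, no measured pair changes the halogen, so neither of the steps above bears directly on this change; what they show is only that small alterations elsewhere in the shared core have moved this assay by amounts inside the scatter. On that basis no step beyond the scatter is expected for compound 4, and the estimated change is no change at the digits printed from compound 3 to compound 4 (within the scatter). Compound 4 is expected to give about 600 mg/kg, within a range of 350 mg/kg to 1000 mg/kg.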

Compound 4, dose for half-maximal effect: > 800 mg/kg
Compound 4 was reported as a limit (the forecaster's own chance of this, stated with the estimate: 10%); at least 1.3-fold (0.12 log units) between middle value and limit.
By their numbers in this assay, from the lowest: compounds 1, 2 and 3 (each within the scatter of the next). At a limit, above all of these: compound 4.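

In this assay compound 4 gives > 800 mg/kg, a limit of the assay and not a number. Among the compounds shown here, this is the first change at this position on the aromatic ring, para to a large group, and chloro in place of bromo gives an at least 1.3-fold higher number from compound 3 to compound 4 (0.12 log units; that floor lies within the scatter), a floor that does not by itself separate the two compounds, while the step has no known upper end, unlike the earlier steps, which were closed readings within the scatter. The halogen position therefore cannot yet be called silent in the way the configuration and the amide substituent appeared to be, and the true size of the step remains unknown, with only the limit itself to speak to it: the limit of > 800 mg/kg in this assay, at which 1 of the 4 values shown sits.

The compounds shown leave open whether a group of another kind at this position, such as fluoro, methoxy or a carboxylic acid, would stay in the same range of numbers or move clear of the scatter. They also leave open whether chloro in place of bromo would give a similar step in the drawn configuration of compound 1 or with the allyl group of compound 2 on the amide nitrogen.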